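The source may report more compounds than this note shows. Statements on the series, on what has been measured and on what is new or still open speak of the compounds shown alone.

Measured compounds:
compound 1, `COC(=O)/C=C/c1cccc(N(Cc2ccc(-c3ccc(SC)cc3)cc2)C(=O)C(C)C)c1`, 51 nM in an assay on isolated protein with Bile acid receptor (Homo sapiens) as the target; on this read-out lower numbers stand for an effect already at smaller amounts and higher numbers for an effect only at larger amounts of compound
compound 2, `COC(=O)/C=C/c1cccc(N(Cc2ccc(-c3ccc(SC)cc3)cc2)C(=O)C2CCCCC2)c1`, 69 nM in this assay

Among these two numbers compound 1 has the lower one, and compound 2 lies a 1.4-fold higher number from compound 1 to compound 2 (0.13 log units; within the scatter), a gap within the scatter, so the two cannot be ordered. That single step swaps the group on the carbonyl carbon, a different place from the change that leads to compound 3, `COC(=O)/C=C/c1cccc(N(Cc2ccc(/C=C/c3cccc(Cl)c3)cc2)C(=O)C(C)C)c1`. Compound 3 differs from compound 1 as follows: 2-(3-chlorophenyl)ethenyl in place of 4-(methylsulfanyl)phenyl on an aromatic carbon. Among the compounds with values here, no measured step touches this part of the molecule, so the data give no direct guide to the direction or size of the change. Since the groups leaving and entering are of similar size, compound 3 is expected to stay near compound 1, with a 1.6-fold higher number from compound 1 to compound 3 (0.20 log units; within the scatter) as the expected step and a wide range. Compound 3 is therefore estimated at 80 nM in this assay, between 25 nM and 300 nM.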

Compound 3, half-maximal effective concentration: 164 nM
The estimate for compound 3 lay 2.1-fold (0.31 log units) below the measured number; measured number inside the range.
By their numbers in this assay, from the lowest: compounds 1 and 2 (each within the scatter of the next); then compound 3.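

The earlier pair changed only the group on the carbonyl carbon, and that step stayed within the scatter. Within the data shown here, replacing 4-(methylsulfanyl)phenyl with 2-(3-chlorophenyl)ethenyl on the aromatic carbon gives a 3.2-fold higher number from compound 1 to compound 3 (0.51 log units; beyond the scatter) in this assay and is the first step here to exceed the scatter, so this position responds to a change even though both groups carry one six-membered aromatic ring of carbon only. Nothing available explains this rise in the number.

On these data alone, the double bond, the chlorine and the loss of the sulfur all arrive in one step, so it remains open which of them matters. Also open, as far as these compounds go, is how this position would respond to a different kind of group, such as an aminophenyl ring, a carboxyphenyl ring or a longer alkyl chain.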